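The compounds below may be only part of what the source reports. "The series", "measured", "known", "first", "only" and "open" are said of these compounds alone.

In a functional assay on MDA-MB-231 cells (Homo sapiens) for cytotoxicity, read by MTT assay, with a stated time of 72 h (a higher number here means a weaker inhibitor, a lower number a stronger inhibitor), the measured compounds stand as follows:
- compound 1 `CN1CCN(CCCCn2c3c(c4ccccc42)C(=O)c2c[n+]([O-])c4ccccc4c2C3=O)CC1` gives 110 nM
- compound 2 `O=C1c2c[n+]([O-])c3ccccc3c2C(=O)c2c1c1ccccc1n2CCCCN1CCNCC1` gives 3310 nM
- compound 3 `CN(C)CCCCn1c2c(c3ccccc31)C(=O)c1c[n+]([O-])c3ccccc3c1C2=O` gives 350 nM

Compound 3 holds the second highest of the three numbers, closer to compound 1 than to compound 2. The change to compound 4 `CN1CCN(CCCCCn2c3c(c4ccccc42)C(=O)c2c[n+]([O-])c4ccccc4c2C3=O)CC1` is (4-methylpiperazin-1-yl)methyl in place of dimethylamino on a saturated chain carbon, four bonds along the chain from an aromatic nitrogen and the same difference reads 3-(dimethylamino)propyl to 4-(4-methylpiperazin-1-yl)butyl.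

The closest evidence is a 3.2-fold higher number from compound 1 to compound 3 (0.50 log units; beyond the scatter) which, read backwards, favours the 4-methylpiperazin-1-yl end over dimethylamino by a modest margin. Compound 2 shows how much the methyl on the ring nitrogen matters, with a 30-fold higher number from compound 1 to compound 2 (1.48 log units; beyond the scatter) and a 9.5-fold lower number from compound 2 to compound 3 (0.98 log units; beyond the scatter) as the measured steps, and compound 4 keeps that methyl. Within the data shown here, no measured step covers the chain difference between compound 1 and compound 4, so the gain is discounted slightly. A modest move to a lower number is therefore expected in this assay and the expected step is a 2.3-fold lower number from compound 3 to compound 4 (0.37 log units; beyond the scatter) as estimated here. Expected for compound 4 is 150 nM with an estimated range from 50 nM to 450 nM in this assay.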

Compound 4, half-maximal inhibitory concentration: 2270 nM
Compound 4: the middle estimate sits 15-fold (1.18 log units) below what was measured; the measured number lies above the stated range.
By their numbers in this assay, from the lowest: compound 1; then compound 3; then compounds 4 and 2 (each within the scatter of the next).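

In this assay, the gain from the 4-methylpiperazin-1-yl end does not survive (4-methylpiperazin-1-yl)methyl in place of 4-methylpiperazin-1-yl on this chain (a 21-fold higher number from compound 1 to compound 4 (1.31 log units; beyond the scatter)), so chain length matters here as much as the amine end. Against dimethylamino, the longer 4-(4-methylpiperazin-1-yl)butyl chain now loses (a 6.5-fold higher number from compound 3 to compound 4 (0.81 log units; beyond the scatter)), reversing the order seen for compound 1 and compound 3, and it stands level with the piperazin-1-yl end of compound 2 (a 1.5-fold lower number from compound 2 to compound 4 (0.16 log units; within the scatter)). Nothing available accounts for this sensitivity to the chain.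

Open, on these data alone, is whether a longer chain carrying dimethylamino or piperazin-1-yl would lose as much as compound 4 does. Also open, as far as these compounds go, is how a shorter chain, or a morpholin-4-yl end, would read at this position.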